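Dropping the Dimethylamino Group: From Compound 1 to Compound 4

The source may hold more compounds than are shown below. What is called first, only, known or untested is meant among the compounds shown, and "the series" means these compounds.

Measured compounds:
- compound 1, `CN(C)c1nc(NC2CCC(NS(=O)(=O)c3ccc(Br)cc3OC(F)(F)F)CC2)nc2ccccc12`: in an assay on HEK293 cells for inhibition of melanin-concentrating hormone receptor 1 (Homo sapiens) (on this read-out lower numbers stand for stronger inhibition and higher numbers for weaker inhibition), compound 1 gives 2200 nM
- compound 2, `CCCCCCCCS(=O)(=O)NCC1CCC(CNc2nc(N(C)C)c3ccccc3n2)CC1`: compound 2 gives 6700 nM
- compound 3, `CN(C)c1nc(NCC2CCC(CNS(C)(=O)=O)CC2)nc2ccccc12`: compound 3 gives > 10000 nM, a limit of the assay and not a number, so that compound 3 sits at the limit of > 10000 nM in this assay, at which 1 of the 3 values shown sits.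

Among the two real numbers in this assay, compound 1 stands lowest; compound 2 lies higher by a margin beyond the usual scatter. Compound 4, `O=S(=O)(NC1CCC(Nc2ncc3ccccc3n2)CC1)c1ccc(Br)cc1OC(F)(F)F`, differs from compound 1 in one place: hydrogen in place of dimethylamino on an aromatic carbon of the shared core. Within the data shown here, the only measured step, an at least 1.4-fold higher number from compound 2 to compound 3 (0.17 log units; that floor lies within the scatter), alters the chain on the sulfonyl side and leaves the core untouched, so it does not bear on this change; no measured pair shows what removing the dimethylamino does. The direction is therefore open, and the expectation rests on compound 1 alone, with a wide range around it. The step is estimated at a 1.8-fold higher number from compound 1 to compound 4 (0.26 log units; within the scatter), and compound 4 is expected to give about 4000 nM, between 800 nM and 20000 nM.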

Compound 4, half-maximal inhibitory concentration: 83 nM
Estimate against measurement, compound 4: 48-fold (1.68 log units) above; the measured number lies below the stated range.
By their numbers in this assay, from the lowest: compound 4; then compound 1; then compound 2. At a limit, above all of these: compound 3.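

Removing the dimethylamino group from this aromatic carbon, the only change shown that touches the shared core, gives in this assay a 27-fold lower number from compound 1 to compound 4 (1.42 log units; beyond the scatter), a step well beyond the usual scatter. This position therefore matters strongly for this read-out, and on this core the dimethylamino group is not needed, since the plain hydrogen of compound 4 gives a far lower number. None of the evidence at hand accounts for the size of this step.

Going by these compounds, only dimethylamino and hydrogen can be compared at this carbon, so what a methyl group, a primary amine or a chlorine atom would give there remains open. Also open, on these data alone, is whether the same exchange would give a similar step on compound 2, whose sulfonyl side differs.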